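The source may hold more compounds than are shown below. What is called first, only, known or untested is meant among the compounds shown, and "the series" means these compounds.

Working notes on the series. For the measured compounds named here, in a functional assay on MIA PaCa-2 cells (Homo sapiens) for inhibition, read by MTT assay, with a stated time of 3 days (a higher number here means a weaker inhibitor, a lower number a stronger inhibitor), compound 2 `CCN(CC)C(=O)c1ccc(S(=O)(=O)N2CCC[C@@H](C(=O)N3CCN(c4nc(C(C)C)no4)CC3)C2)cc1` gives 70 nM, the lowest number of the three measured so far. The gap to each of the other two lies beyond the scatter: compound 3 `CCN(CC)S(=O)(=O)c1ccc(S(=O)(=O)N2CCC[C@@H](C(=O)N3CC4(CN(C(=O)OC(C)(C)C)C4)C3)C2)cc1` gives 300 nM, and compound 1 `CCN(CC)S(=O)(=O)c1ccc(S(=O)(=O)N2CCC[C@@H](C(=O)NC3CN(C(=O)C4CC4)C3)C2)cc1` gives 3100 nM.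

Next in line is compound 4 `CCN(CC)S(=O)(=O)c1ccc(S(=O)(=O)N2CCC[C@@H](C(=O)N3CCN(c4nc(C(C)C)no4)CC3)C2)cc1`, which has diethylsulfamoyl in place of diethylcarbamoyl on an aromatic carbon, keeping the rest of compound 2 unchanged: diethylsulfamoyl in place of diethylcarbamoyl on an aromatic carbon.

Going by the values given here, no measured pair isolates this swap, so the expectation in this assay rests on thin evidence. The diethylsulfamoyl group already appears in compound 3 at 300 nM and in compound 1 at 3100 nM. Both numbers are higher than that of compound 2, but both compounds also differ from it elsewhere, so neither value can be credited to this group. A small step towards a weaker number is therefore expected, quite possibly none beyond the scatter. The expected change is a 1.7-fold higher number from compound 2 to compound 4 (0.23 log units; within the scatter). For compound 4 the estimated value is 120 nM, with an expected range of 40 nM to 400 nM.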

Compound 4, half-maximal inhibitory concentration: 30 nM
Compound 4: middle estimate off by 4.0-fold (0.60 log units), on the high side; measured number below the stated range.
By their numbers in this assay, from the lowest: compound 4; then compound 2; then compound 3; then compound 1.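

In this assay, the pair compound 2 and compound 4 isolates one change, diethylsulfamoyl in place of diethylcarbamoyl on an aromatic carbon para to a large group, with the rest of the structure held constant; it gives a 2.3-fold lower number from compound 2 to compound 4 (0.37 log units; beyond the scatter). Until now, diethylsulfamoyl had appeared only in compounds that also differed elsewhere from compound 2, whereas this pair shows that, with the remainder of compound 2 in place, the group is tolerated at this position and gives a modest step towards a stronger inhibitor. No measurement is available that accounts for the direction or size of this step.

The compounds shown do not reveal whether the same swap would give a similar step in the settings of compound 1 and compound 3, since neither has a diethylcarbamoyl counterpart here. Also open, on these data alone, is how this position would respond to other groups, such as dimethylsulfamoyl with its shorter chains, a pyrrolidine-1-sulfonyl group with the two ethyl chains tied into a ring, or a carboxylic acid.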